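Methoxy in place of phenyl: a step from a limit

The source may hold more compounds than are shown below. What is called first, only, known or untested is meant among the compounds shown, and "the series" means these compounds.

In a functional assay on T47D cells (Homo sapiens) for cytotoxicity, read by MTT assay, with a stated time of 48 h (a lower number here means a stronger inhibitor, a higher number a weaker inhibitor), compound 1 `COc1cc(-n2c(-c3ccc(Cl)cc3Cl)csc2=S)cc(OC)c1OC` gives 43.4 ug/mL. Going by these compounds, compound 2 `COc1cc(-n2c(-c3ccc(-c4ccccc4)cc3)csc2=S)cc(OC)c1OC` stands at > 100 ug/mL, which is a limit of the assay and not a number, so its true position is unknown. Compound 3 `COc1ccc(-c2csc(=S)n2-c2cc(OC)c(OC)c(OC)c2)cc1` carries methoxy in place of phenyl on an aromatic carbon. For the measured compounds named here, no measured step shows what this change does, though compound 1 at 43.4 ug/mL shows that a number can be reached on the shared core. A modest move toward stronger inhibition is expected in this assay, estimated as an at least 1.6-fold lower number from compound 2 to compound 3 (0.22 log units; that floor lies within the scatter). For compound 3 the expected value is 60 ug/mL, with an estimated range of 25 ug/mL to 120 ug/mL.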

Compound 3, half-maximal inhibitory concentration: > 100 ug/mL
Compound 3: a limit, no number; the forecaster's own chance of this, stated with the estimate: 30%; middle value at least 1.6-fold (0.22 log units) from the limit.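

With methoxy on this aromatic carbon, compound 3 gives > 100 ug/mL in this assay, which is a limit and not a number. So the smaller group, like phenyl, reaches no number on the shared core, and of the compounds shown only compound 1 does. 4-Methoxyphenyl in place of 2,4-dichlorophenyl gives an at least 2.3-fold higher number from compound 1 to compound 3 (0.36 log units; beyond the scatter), while the step between compound 2 and compound 3 cannot be read because both values are limits: the limit of > 100 ug/mL in this assay, at which 2 of the 3 values shown sit.

Going by these compounds, what stays open is whether an amine or a carboxylic acid on this aromatic carbon would bring a number in this assay.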